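This account rests on a few compounds, and the source may have more. Where it says the series, first, only, none or still open, it means among the compounds named here.

Compound 2 `CN1C[C@@H](c2ccc(Cl)cc2)[C@@]2(Cc3ccccc3C2=O)[C@@]12C(=O)Nc1ccccc12` was examined alongside compound 1 `CN1C(=O)[C@@]2(c3ccccc31)N(C)C[C@@H](c1ccc(F)cc1)[C@@]21Cc2ccccc2C1=O`, and both were measured in a functional assay on the whole organism (strain Wister albino) for inhibition, with Rattus norvegicus as the target, read by paw edema, with stated times of 1 h and 2 h, at a dose of 50 mg/kg by the intraperitoneal route; on this read-out lower numbers stand for less inhibition and higher numbers for more inhibition at the one dose given (going by the name of the read-out). Of the two numbers in hand, compound 2 gives the higher one, 28.4%, while compound 1 gives 24.6%; the gap between them lies within the usual scatter, so the two compounds cannot be told apart on this read-out. Compound 1 and compound 2 differ in more than one place. Among the compounds with values here, their two values show only that the pair sits in the same range.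

Compound 3 `CN1C(=O)[C@@]2(c3ccccc31)N(C)C[C@@H](c1ccc(Cl)cc1)[C@@]21Cc2ccccc2C1=O` has not yet been measured in this assay. It differs from compound 2 in one place: methyl in place of hydrogen on an amide-type nitrogen in a ring. Within the data shown here, no step of this kind between measured compounds is available, so the expected size of the change rests only on the two numbers already seen. With compound 2 at 28.4% and compound 1 at 24.6%, the two measured compounds lie close together, and the step from compound 2 to compound 3 is expected to be no larger than the scatter, a number 2.4 percentage points lower from compound 2 to compound 3 (within the scatter). Compound 3 is therefore estimated at 26%, with a likely range from 17% to 35%.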

Compound 3, a percentage reported as inhibition, in the whole organism at one dose (the size of the read-out at that dose, not a potency): 36.3%
The estimate for compound 3 lay 10.3 percentage points below the measured number; the measured number lies above the stated range.
By their numbers in this assay, from the lowest: compounds 1, 2 and 3 (each within the scatter of the next, the first and the last beyond it).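

In this assay, methyl in place of hydrogen on the amide-type nitrogen in a ring can now be read as a single change: it gives a number 7.9 percentage points higher from compound 2 to compound 3 (within the scatter), so this substitution on the nitrogen does not separate the two compounds on this read-out. With methyl on that nitrogen in both compounds, chloro in place of fluoro on an aromatic carbon gives a number 11.7 percentage points higher from compound 1 to compound 3 (beyond the scatter), a modest step and the only one of the two that lies beyond the scatter. Nothing at hand explains why the halogen step registers on this read-out and the nitrogen step does not.

The compounds shown leave open how a methoxy group, a trifluoromethyl group or a plain hydrogen on that aromatic carbon would read, and likewise a longer chain such as ethyl or a benzyl group on the amide-type nitrogen. The halogen step is also known only with methyl on the nitrogen, so whether it would hold with the amide hydrogen in place remains an open question.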